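A few compounds are considered here, and "the series" means these few. Any claim that something is new, unique, unknown or untested is made for them only; others in the source may bear on it.

Measured compounds:
Compound 1, `COc1n[nH]c2ncc(-c3cn(-c4c(F)ccc(NS(=O)(=O)c5cccc(Cl)c5)c4F)nn3)cc12`, gives 1.9 nM in an assay on Sf9 cells for inhibition of mitogen-activated protein kinase kinase kinase 20 (Homo sapiens), read by ADP-Glo, with a stated time of 30 min; a lower number here means a stronger inhibitor, a higher number a weaker inhibitor.
Compound 2, `Nc1ccc(-c2cn(-c3c(F)ccc(NS(=O)(=O)c4cccc(Cl)c4)c3F)nn2)cn1`, gives 46.2 nM in this assay.
Compound 3, `COc1n[nH]c2ncc(-c3cn(-c4cc(NS(=O)(=O)c5cccc(Cl)c5)ccc4F)nn3)cc12`, gives 5.7 nM in this assay.

Compound 1 holds the lowest number of the three. The nearest neighbour is compound 3, a 3.0-fold higher number from compound 1 to compound 3 (0.48 log units; beyond the scatter), and the furthest is compound 2, a 24-fold higher number from compound 1 to compound 2 (1.39 log units; beyond the scatter). Both of those steps alter the part of the molecule attached to the triazole, not the sulfonyl aryl ring.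

Compound 4, `COc1n[nH]c2ncc(-c3cn(-c4c(F)ccc(NS(=O)(=O)c5cccc(C#N)c5)c4F)nn3)cc12`, is built from compound 1 by a change at the other end: cyano in place of chloro on an aromatic carbon. Neither measured step touches this ring, so the two steps give no direct guide; the same size of step as in the two larger changes is not to be read into a one-atom swap on the sulfonyl aryl ring. Without a measured counterpart, the expectation for compound 4 rests on the change being small in size. Compound 4 is expected to give 3 nM in this assay, within a range from 1.2 nM to 8 nM. This means an expected step of a 1.6-fold higher number from compound 1 to compound 4 (0.20 log units; within the scatter), likely not beyond the scatter.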

Compound 4, half-maximal inhibitory concentration: 3.3 nM
Compound 4: the middle estimate sits 1.1-fold (0.04 log units) below what was measured; low and high end bracket the measured number.
By their numbers in this assay, from the lowest: compounds 1, 4 and 3 (each within the scatter of the next, the first and the last beyond it); then compound 2.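

Among the compounds shown here, the three earlier compounds all carry the 3-chlorophenyl group, so compound 4 gives the first reading at this end of the molecule. In this assay, cyano in place of chloro on this ring, meta to a large group, gives a 1.7-fold higher number from compound 1 to compound 4 (0.24 log units; within the scatter) and so leaves the two compounds indistinguishable, which shows that this position accepts a two-atom cyano group as well as a single chlorine without a change beyond the scatter. No measurement at hand bears on why these two groups read alike.

The compounds shown leave open whether a bare hydrogen, an amine or a carboxylic acid at this position would read the same. They also leave open whether the same swap would read alike on the structures of compound 2 or compound 3.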